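The source may report more compounds than this note shows. Statements on the series, on what has been measured and on what is new or still open speak of the compounds shown alone.

Among the compounds with values here, compound 3 `O=C(/C=C/c1ccc([N+](=O)[O-])s1)c1ccc(C2CCCCC2)cc1` sits at the upper end of the numbers so far. In an ADME assay on THP-1 cells (Homo sapiens) for cytotoxicity, read by resazurin assay, with a stated time of 72 h (a lower number here means that less compound is tolerated, a higher number that more compound is tolerated), compound 3 gives > 50000 nM, which is a limit of the assay rather than a number (the limit of > 50000 nM in this assay, at which 1 of the 3 values shown sits). Compound 1 `CCCCc1ccc(C(=O)/C=C/c2ccc([N+](=O)[O-])s2)cc1` gives 17100 nM in this assay, and compound 2 `O=C(/C=C/c1ccc([N+](=O)[O-])s1)c1ccc(-n2ccnc2)cc1` gives 23400 nM. The step from compound 1 to compound 3 was an at least 2.9-fold higher number from compound 1 to compound 3 (0.46 log units; beyond the scatter), and the step from compound 2 to compound 3 was an at least 2.1-fold higher number from compound 2 to compound 3 (0.32 log units; beyond the scatter).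

Compound 4 `Cc1ccc(C(=O)/C=C/c2ccc([N+](=O)[O-])s2)cc1` differs from compound 3 in one place: methyl in place of cyclohexyl on an aromatic carbon. The two steps that bear on this change both run toward cyclohexyl and both raised the number at least modestly; the present step runs away from cyclohexyl toward a smaller substituent, as in compound 1, whose butyl is the closest measured point. He therefore expects a drop beyond the scatter for compound 4 in this assay, an at least 2.7-fold lower number from compound 3 to compound 4 (0.44 log units; beyond the scatter), back toward the range of compound 1. His estimate for compound 4 in this assay is 18000 nM, expected to fall between 8000 nM and 45000 nM.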

Compound 4, half-maximal cytotoxic concentration: 13500 nM
Estimate against measurement, compound 4: 1.3-fold (0.12 log units) above; measured number inside the range.
By their numbers in this assay, from the lowest: compounds 4, 1 and 2 (each within the scatter of the next). At a limit, above all of these: compound 3.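

With cyclohexyl replaced by methyl on this aromatic carbon, this assay gives an at least 3.7-fold lower number from compound 3 to compound 4 (0.56 log units; beyond the scatter) and so shows that cyclohexyl stands apart from a third group, and from one with a single carbon and no ring. Methyl itself does not separate from the other two groups, with a 1.7-fold lower number from compound 2 to compound 4 (0.24 log units; within the scatter) and a 1.3-fold lower number from compound 1 to compound 4 (0.10 log units; within the scatter) both inside the scatter, so among compound 1, compound 2 and compound 4 this position shows no order. Compound 3 remains a limit and not a number, so its gap to compound 4 is a bound only: the limit of > 50000 nM in this assay, at which 1 of the 4 values shown sits.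

The compounds shown leave open whether the separation belongs to cyclohexyl alone or extends to another saturated ring such as cyclopentyl or to a branched group such as tert-butyl. They also say nothing of how an amine or a carboxylic acid would behave on this aromatic carbon.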